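Nitro to Fluoro Exchange Across Two Related Scaffolds

A few compounds are considered here, and "the series" means these few. Any claim that something is new, unique, unknown or untested is made for them only; others in the source may bear on it.

Of the compounds shown here, three have so far been tested in a functional assay on CCRF-CEM cells (Homo sapiens) for cytotoxicity, in the absence of a further agent; on this read-out lower numbers stand for stronger inhibition and higher numbers for weaker inhibition. Compound 1 `CC(C)(C)OC(=O)CCC(Nc1ccc(CN(CCCc2c(N)nc(N)nc2O)c2ccc([N+](=O)[O-])c(F)c2[N+](=O)[O-])cc1)C(=O)OC(C)(C)C` gives 3200 nM there. Compound 2 `Nc1nc(N)c(CCCNc2cc(F)c([N+](=O)[O-])cc2[N+](=O)[O-])c(O)n1` gives 1000 nM in this assay, the lowest number of the three, and compound 3 `CC(C)(C)OC(=O)CCC(Nc1ccc(CN(CCCc2c(N)nc(N)nc2O)c2ccc([N+](=O)[O-])c(F)c2F)cc1)C(=O)OC(C)(C)C` gives 24000 nM. Compound 2 carries a smaller core than compound 1, and the difference between the two cores is not broken down here.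

Compounds 1 and 3 differ in a single place: fluoro in place of nitro on an aromatic carbon. This exchange produced a 7.5-fold higher number from compound 1 to compound 3 (0.88 log units; beyond the scatter), so the compound carrying fluoro in that position inhibits growth less strongly than the one carrying nitro.

Compound 4 `Nc1nc(N)c(CCCNc2cc(F)c(F)cc2[N+](=O)[O-])c(O)n1` has not yet been measured. It stands to compound 2 as compound 3 stands to compound 1, since (fluoro in place of nitro on an aromatic carbon). The surroundings are not identical, though: in compound 1 the changed carbon is ortho to a large group, whereas in compound 2 it is para to a large group, so the two exchanges are the same kind of change rather than the same change.

Because compound 2 starts from 1000 nM and the analogous exchange gave a 7.5-fold higher number from compound 1 to compound 3 (0.88 log units; beyond the scatter), a weakening of comparable size is expected for compound 4, estimated as a 5.0-fold higher number from compound 2 to compound 4 (0.70 log units; beyond the scatter). Compound 4 is therefore expected to give about 5000 nM in this assay, most likely between 1500 nM and 20000 nM.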

Compound 4, half-maximal inhibitory concentration: 97000 nM
The estimate for compound 4 lay 19-fold (1.29 log units) below the measured number; the whole stated range lies below it.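

In this assay, putting fluoro in place of nitro on an aromatic carbon gives a 97-fold higher number from compound 2 to compound 4 (1.99 log units; beyond the scatter), so the exchange weakens inhibition on this core too, in the same direction as on the core of compound 1. The direction therefore carries over from one core to the other, but the size does not, and a step measured on one core gives only a rough guide to the step on the other: the same change on two cores in this assay, a 7.5-fold higher number (0.88 log units; beyond the scatter) from compound 1 to compound 3 and a 97-fold higher number (1.99 log units; beyond the scatter) from compound 2 to compound 4, 13-fold (1.11 log units) apart, beyond the scatter of two such steps These two pairs do not show what produces the gap, since the cores differ and the changed carbon also has different surroundings in each, and the data cannot separate these two differences; two pairs are also too few to set a rule for the wider series.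

What the compounds shown leave open is whether another group in that place, such as a nitrile, a chloro group or a trifluoromethyl group, would keep more of the inhibition seen with nitro on either core. Going by these compounds, it also remains open whether the exchange would behave the same way on the larger core with a carboxylic acid in place of its esters.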